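The source may hold more compounds than are shown below. What is called first, only, known or untested is meant among the compounds shown, and "the series" means these compounds.

Measured in a functional assay on A549 cells (Homo sapiens) for antiproliferative activity, read by MTT assay, with a stated time of 48 h; a higher number here means a weaker inhibitor of growth, a lower number a stronger inhibitor of growth:
- compound 1 `COC(=O)N1N=C(c2cccc(O)c2)CC1c1cc(OC)c(OC)c(OC)c1`: 3170 nM
- compound 2 `CCCOC(=O)N1N=C(c2cccc(O)c2)CC1c1cc(OC)c(OC)c(OC)c1`: > 10000 nM

Going by the values given here, compound 1 carries the only actual number on this scale, 3170 nM. Compound 2 reaches only a limit, > 10000 nM, and not a number.

Compound 3 `COC(=O)N1N=C(c2ccc(OC)c(OC)c2)CC1c1cc(OC)c(OC)c(OC)c1` keeps the core of compound 1 and its methoxycarbonyl group, but the group on the carbon with a double bond to nitrogen is exchanged: 3,4-dimethoxyphenyl in place of 3-hydroxyphenyl on a carbon with a double bond to nitrogen. The hydrogen-bond donor of the 3-hydroxyphenyl group is therefore gone in compound 3.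

Among the compounds with values here, only one measured step is available, an at least 3.1-fold higher number from compound 1 to compound 2 (0.49 log units; beyond the scatter). It lies at the ester chain rather than at the place changed here, so it bears on this change only indirectly. It does show that compound 1 can lose activity in this assay through a single small alteration. Within the data shown here, no measured step tests the 3-hydroxyphenyl group itself, so the expectation is loose: a modest move toward a higher number, with no change beyond the scatter also possible. The estimated change is a 1.6-fold higher number from compound 1 to compound 3 (0.20 log units; within the scatter). For compound 3 the expected value is 5000 nM, with an estimated range from 1300 nM to 15000 nM.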

Compound 3, concentration for 50% growth inhibition: 3930 nM
Estimate against measurement, compound 3: 1.3-fold (0.10 log units) above, and the stated range covers the measured number.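

In this assay, the exchange of 3-hydroxyphenyl for 3,4-dimethoxyphenyl on a carbon with a double bond to nitrogen gives a 1.2-fold higher number from compound 1 to compound 3 (0.09 log units; within the scatter). Going by these compounds alone, this is the first measured change at this position, and it shows that, for this pair, the number stays within the scatter although the group that enters carries no hydrogen-bond donor and has more heavy atoms than the group that leaves. Compound 2, changed at the ester chain and not at this position, stands at a limit of the assay and not at a number: the limit of > 10000 nM in this assay, at which 1 of the 3 values shown sits.

The step from compound 1 to compound 3 alters the hydroxyl group and adds methoxy substitution in one move, so the two contributions cannot be told apart, and a 3-methoxyphenyl group would be needed to separate them. On these data alone, it also remains open whether other groups at this position, such as an unsubstituted phenyl or an aminophenyl group, would keep the number within the scatter of compound 1 or move it beyond.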